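Swapping a chloro position on a triazole-linked phenyl ring

The source may hold more compounds than are shown below. What is called first, only, known or untested is meant among the compounds shown, and "the series" means these compounds.

Compound 1, `O=c1[nH]cc(S(=O)(=O)Nc2ccc(-c3cn(-c4ccccc4)nn3)cc2)c(=O)[nH]1`: "not toxic" (no number reported)
Compound 2, `O=c1[nH]cc(S(=O)(=O)Nc2ccc(-c3cn(-c4ccc(F)cc4)nn3)cc2)c(=O)[nH]1`: "not toxic" (no number reported)
Compound 3, `O=c1[nH]cc(S(=O)(=O)Nc2ccc(-c3cn(-c4cccc(Cl)c4)nn3)cc2)c(=O)[nH]1`: 19000 nM

Three compounds share one core and differ only in the ring attached to an aromatic nitrogen of the triazole. Among the compounds with values here, in an ADME assay on L02 cells (Homo sapiens) for cytotoxicity, read by MTT assay, with a stated time of 24 h (on this read-out lower numbers stand for higher toxicity in this test and higher numbers for lower toxicity in this test), compound 1 gives "not toxic" (no number reported) and compound 2 gives "not toxic" (no number reported), both without a number, so no step between measured compounds can be computed. Within the data shown here, compound 3 is the only one with a number in this assay, 19000 nM, which places it alone on the scale; nothing shows whether it is more or less toxic than compound 1 or compound 2.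

Compound 4, `O=c1[nH]cc(S(=O)(=O)Nc2ccc(-c3cn(-c4ccc(Cl)cc4)nn3)cc2)c(=O)[nH]1`, has the same atoms as compound 3 but joined differently: 4-chlorophenyl in place of 3-chlorophenyl on an aromatic nitrogen. The change is a move of a single chlorine around an aromatic ring, with no change in count, donors or acceptors. Among the measured compounds shown here, no measured pair shows what such a move does here. With so little to rest on, compound 4 is expected to stay close to compound 3, with the expected step from compound 3 to compound 4, no change at the digits printed from compound 3 to compound 4 (within the scatter), lying within the usual scatter. The estimate for compound 4 in this assay is 19000 nM, expected between 8000 nM and 45000 nM.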

Compound 4, half-maximal cytotoxic concentration: 42900 nM
Estimate against measurement, compound 4: 2.3-fold (0.35 log units) below; the range from low to high includes it.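

Moving the chlorine from 3-chlorophenyl to 4-chlorophenyl on the aromatic nitrogen gives a 2.3-fold higher number from compound 3 to compound 4 (0.35 log units; beyond the scatter) in this assay, the first step between two numbers in this series. A higher number here stands for lower toxicity in this test, so the 4-chlorophenyl group reads as the less toxic of the two chlorinated rings, by a modest margin. The atoms and counts stay the same, so only where the chlorine sits has changed, and nothing measured here explains why that matters.

Compound 1 and compound 2 carry no number, so any steps from them cannot be read. As far as these compounds go, it also remains open how this ring would behave with an amine or a carboxylic acid in place of the chlorine.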